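Removing the Nitrile: A Substituent Change in a CAR Agonist Series

A few compounds are considered here, and "the series" means these few. Any claim that something is new, unique, unknown or untested is made for them only; others in the source may bear on it.

The measured compounds:
- compound 1, `N#Cc1ccc(-c2nc3sccn3c2/C=N/OCc2ccc(Cl)c(Cl)c2)cc1`, 3400 nM in an assay on HepG2 cells for agonist activity at nuclear receptor subfamily 1 group I member 3 (Homo sapiens), read by a luciferase reporter, with a stated time of 23 h; a lower number here means that less compound is needed, a higher number that more compound is needed for the effect
- compound 2, `C(=N/OCc1ccccc1)\c1c(-c2ccc3ccccc3c2)nc2occn12`, 840 nM in this assay
- compound 3, `FC(F)(F)c1ccc(CO/N=C/c2c(-c3ccc4ccccc4c3)nc3occn23)cc1`, 470 nM in this assay

Compound 1 stands highest of the three in this assay; compound 2 is its nearest neighbour and compound 3 its furthest, and both gaps lie beyond the usual scatter of this kind of measurement.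

Compound 4, `Clc1ccc(CO/N=C/c2c(-c3ccccc3)nc3sccn23)cc1Cl`, has not yet been measured. Set against compound 1, the change is hydrogen in place of cyano on an aromatic carbon.

Going by the values given here, only one measured step is available, a 1.8-fold lower number from compound 2 to compound 3 (0.25 log units; within the scatter), and it concerns a different position on a different part of the molecule: a change on the benzyl group rather than on the aryl group attached to the shared core. Among the compounds with values here, no step in these data alters the aryl group directly, and compounds 2 and 3 differ from compound 1 in core and in aryl group at the same time, so they give no clean guide to the loss of the nitrile alone.

Within the data shown here, with no directly bearing step, the expectation for compound 4 is a small shift, estimated as a 1.4-fold lower number from compound 1 to compound 4 (0.13 log units; within the scatter), which lies within the scatter. The estimated value for compound 4 in this assay is 2500 nM, with a range from 800 nM to 8000 nM.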

Compound 4, half-maximal effective concentration: 580 nM
Compound 4: the middle estimate sits 4.3-fold (0.63 log units) above what was measured; measured number below the stated range.
By their numbers in this assay, from the lowest: compounds 3, 4 and 2 (each within the scatter of the next); then compound 1.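

Swapping cyano for hydrogen on the aromatic carbon para to a large group, which turns 4-cyanophenyl into phenyl, gives a 5.9-fold lower number from compound 1 to compound 4 (0.77 log units; beyond the scatter) in this assay and lies beyond the scatter. This is the only step shown that changes the aryl group on the shared core while everything else stays the same, and it isolates the loss of the nitrile in a way that compounds 2 and 3 could not. It shows that the nitrile is not required for the effect in this series, and that less compound is needed without it; the data on hand give no measured explanation for this shift.

This single pair cannot show whether the same change would have a similar effect on a different core or with a different benzyl group. Nor does it show how other groups at this place, such as a fluorine atom, a methoxy group, an amine or a carboxylic acid, would compare with hydrogen or cyano, so it remains unknown whether hydrogen is the best choice here.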